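Adding a methyl group to compound 2

The source may hold more compounds than are shown below. What is called first, only, known or untested is meant among the compounds shown, and "the series" means these compounds.

Measured in a functional assay on MDA-MB-468 cells (Homo sapiens) for antiproliferative activity; a lower number here means a stronger inhibitor of growth, a higher number a weaker inhibitor of growth:
- compound 1 `COc1ccc(-c2nc3ccccc3s2)cc1OC` gives 530 nM
- compound 2 `COc1ccc(-c2nc3cc(F)ccc3s2)cc1` gives 330 nM

Compound 2 at 330 nM lies within the scatter of compound 1 at 530 nM, so the two cannot be ranked. Compound 3 `COc1ccc(-c2nc3cc(F)ccc3s2)cc1C` has methyl in place of hydrogen on an aromatic carbon, ortho to a methoxy group (methyl in place of hydrogen on an aromatic carbon). For the measured compounds named here, no measured pair tests this change, so the size of the step in this assay remains open. A small move toward a lower number is expected, a 1.7-fold lower number from compound 2 to compound 3 (0.22 log units; within the scatter), and the opposite direction is not excluded. Compound 3 is estimated at 200 nM, within a range of 30 nM to 800 nM.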

Compound 3, concentration for 50% growth inhibition: 58 nM
The estimate for compound 3 lay 3.4-fold (0.54 log units) above the measured number, and the stated range covers the measured number.
By their numbers in this assay, from the lowest: compound 3; then compounds 2 and 1 (each within the scatter of the next).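

In this assay, methyl in place of hydrogen on an aromatic carbon, ortho to a methoxy group and meta to a large group, gives a 5.7-fold lower number from compound 2 to compound 3 (0.76 log units; beyond the scatter) and so lies beyond the scatter. This position therefore responds to a single added carbon, which the earlier pair could not show. Nothing on hand accounts for the size of this step.

The compounds shown leave open whether ethyl, chlorine or an amine at this carbon would match methyl. Going by these compounds, whether methyl gives a similar step without the fluorine of compound 2 also remains open.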